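Swapping Carboxymethyl for (Ethoxycarbonyl)amino in Compound 1

This account rests on a few compounds, and the source may have more. Where it says the series, first, only, none or still open, it means among the compounds named here.

In a functional assay (aorta) with Rattus norvegicus as the target (on this read-out higher numbers stand for weaker inhibition and lower numbers for stronger inhibition), compound 1 (`CC1(C)Oc2ccc(C#N)cc2[C@H](N(CC(=O)O)c2ccccc2)[C@H]1O`) gives > 100000 nM as a limit of the assay and not as a number. Compound 2 (`CCOC(=O)CN(c1ccc(Cl)cc1)[C@H]1c2cc(C#N)ccc2OC(C)(C)[C@@H]1O`) gives > 30000 nM as a limit too. Going by the values given here, compound 1 therefore stands at a limit, like the only other compound tested, and the two readings cannot be put in order.

Compound 3 (`CCOC(=O)NN(c1ccccc1)[C@H]1c2cc(C#N)ccc2OC(C)(C)[C@@H]1O`) shares the core of compound 1 and differs in one place, on a nitrogen on an aromatic ring: (ethoxycarbonyl)amino sits in place of carboxymethyl ((ethoxycarbonyl)amino in place of carboxymethyl on a nitrogen on an aromatic ring). Among the compounds with values here, no measured step between two compounds that differ in one place is available as a guide. The limit for compound 2 at > 30000 nM offers no sign of strong inhibition, so only a modest gain is expected from this swap. In this assay the estimated move is an at least 5.0-fold lower number from compound 1 to compound 3 (0.69 log units; beyond the scatter) toward stronger inhibition, and it may prove small. Compound 3 may well return only a limit again. The estimate for compound 3 is 20000 nM with an expected range from 3000 nM to 100000 nM on this read-out.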

Compound 3, half-maximal inhibitory concentration: 2200 nM
Compound 3: middle estimate off by 9.1-fold (0.96 log units), on the high side; the whole stated range lies above it.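

Going by these compounds alone, on the nitrogen that carries the aromatic ring, the swap produces the only value shown that is a number and not a limit. In this assay, placing (ethoxycarbonyl)amino where carboxymethyl stood gives an at least 45-fold lower number from compound 1 to compound 3 (1.65 log units; beyond the scatter). Within the data shown here, the group on this nitrogen can therefore decide whether a compound built on this shared core stays at a limit or gives a measurable inhibition, and the earlier compounds could not show this. The true size of the step remains unknown because one end of it is a limit and not a number: the limit of > 100000 nM in this assay, at which 1 of the 3 values shown sits.

The entering group differs from the one it replaces in several ways, since it brings a new nitrogen and an ethyl ester while the carboxylic acid leaves, and a single swap cannot tell which of these changes matters or why inhibition improves. Simple amino or the longer (propoxycarbonyl)amino on this same nitrogen would be informative neighbours, as they would show whether the carbonyl part or the length of the chain carries the gain.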